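The source may hold more compounds than are shown below. What is called first, only, known or untested is meant among the compounds shown, and "the series" means these compounds.

Going by the values given here, in a functional assay on A549 cells (Homo sapiens) for cytotoxicity, read by MTT assay, with a stated time of 48 h (on this read-out higher numbers stand for weaker inhibition and lower numbers for stronger inhibition), compound 1 (`COc1cc([C@@H]2C[C@]2(CO)C(=O)NCc2ccc(C)cc2)cc(OC)c1OC`) gives 10500 nM and compound 2 (`CCOC(=O)[C@@]1(C(=O)NCc2ccc(C)cc2)C[C@H]1c1cc(OC)c(OC)c(OC)c1`) gives 17100 nM as the only two numbers so far, which places compound 2 within the usual scatter of compound 1. Compound 3 (`COc1cc([C@@H]2C[C@@]2(CO)C(=O)NCc2ccc(C)cc2)cc(OC)c1OC`) is still to be measured in this assay and differs from compound 2 by hydroxymethyl in place of ethoxycarbonyl on a saturated ring carbon. Among the compounds with values here, no measured step isolates this change, so the expectation rests only on the two close values, with compound 1 at 10500 nM as the nearest guide. A small shift toward a lower number is expected in this assay and may well stay within the scatter (expected step: a 1.4-fold lower number from compound 2 to compound 3 (0.15 log units; within the scatter)). The estimate for compound 3 is 12000 nM with an expected range of 4500 nM to 30000 nM for now.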

Compound 3, half-maximal inhibitory concentration: 46300 nM
Compound 3: the middle estimate sits 3.9-fold (0.59 log units) below what was measured; the measured number lies above the stated range.
By their numbers in this assay, from the lowest: compounds 1 and 2 (each within the scatter of the next); then compound 3.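

In this assay this ring carbon proves sensitive to configuration as drawn, with a 4.4-fold higher number from compound 1 to compound 3 (0.64 log units; beyond the scatter), a difference the two earlier compounds could not reveal. The gap can be attributed to configuration alone because of one fact: the fact that compounds 1 and 3 differ only in the configuration as drawn. The position is also sensitive to the group it carries, since hydroxymethyl in place of ethoxycarbonyl comes with a 2.7-fold higher number from compound 2 to compound 3 (0.43 log units; beyond the scatter).

It remains open how ethoxycarbonyl would read in the opposite configuration at this ring carbon, so the compounds shown do not tell whether the configuration matters equally for both groups. From the compounds shown here alone, it is also open whether a carboxylic acid or an aminomethyl group on the same carbon would read closer to hydroxymethyl or to ethoxycarbonyl, and whether either would depend on configuration in the same direction.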